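A few compounds are considered here, and "the series" means these few. Any claim that something is new, unique, unknown or untested is made for them only; others in the source may bear on it.

Of the compounds shown here, two built on the same core have been tested in a functional assay on NCI-H460 cells (Homo sapiens) for cytotoxicity, read by MTT assay, with a stated time of 72 h; on this read-out lower numbers stand for stronger inhibition and higher numbers for weaker inhibition. Compound 1 `CN(C)CCn1cnnc1-c1cc(Oc2ccc(NC(=O)N/N=C/c3c[nH]c4ccccc34)cc2F)ccn1` gives 1630 nM in this assay. Compound 2 `COc1ccc(OC)c(/C=N/NC(=O)Nc2ccc(Oc3ccnc(-c4nncn4CCN(C)C)c3)c(F)c2)c1` gives 2930 nM in this assay. Within the data shown here, the single step between them, a 1.8-fold higher number from compound 1 to compound 2 (0.25 log units; within the scatter), came with a swap of the group sitting on a carbon with a double bond to nitrogen. Among the two numbers shown, compound 2 holds the larger one, yet its distance from compound 1 lies within the scatter, so the two cannot be told apart with confidence.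

Compound 3 `CN(C)CCn1cnnc1-c1cc(Oc2ccc(NC(=O)N/N=C/c3ccc(O)c(Br)c3)cc2F)ccn1` has not yet been measured. It differs from compound 2 in one place: 3-bromo-4-hydroxyphenyl in place of 2,5-dimethoxyphenyl on a carbon with a double bond to nitrogen. Among the measured compounds shown here, no measured step includes the group that enters; the only step at hand, from compound 1 to compound 2, altered the same place and stayed within the scatter. On that basis, no step beyond the scatter is expected from compound 2 to compound 3, and the expected change is a 1.3-fold lower number from compound 2 to compound 3 (0.12 log units; within the scatter). Compound 3 is therefore estimated at 2200 nM in this assay, with a range from 700 nM to 7000 nM.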

Compound 3, half-maximal inhibitory concentration: 430 nM
The estimate for compound 3 lay 5.1-fold (0.71 log units) above the measured number, and the stated range ends above it.
By their numbers in this assay, from the lowest: compound 3; then compounds 1 and 2 (each within the scatter of the next).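

In this assay, this position turns out to respond to the group placed on it: 3-bromo-4-hydroxyphenyl in place of 2,5-dimethoxyphenyl gives a 6.8-fold lower number from compound 2 to compound 3 (0.83 log units; beyond the scatter), and the same group in place of 1H-indol-3-yl gives a 3.8-fold lower number from compound 1 to compound 3 (0.58 log units; beyond the scatter). Among these compounds, the only earlier change here stayed within the scatter, so it could not show that a swap at this carbon with a double bond to nitrogen can move the number at all; now both steps to the new group lie beyond the scatter, though both are modest in size. The entering group differs from 2,5-dimethoxyphenyl by its bromine and its hydrogen-bond donor, but nothing available here explains the lower number.

The bromine and the hydroxyl arrive together, so the compounds shown cannot separate their contributions, and a phenyl carrying only one of them would be needed to do so. On these data alone, it also remains open whether a chlorine in place of the bromine, or a methoxy in place of the hydroxyl, would keep the lower number.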